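Trimethoxyphenyl cyclopropane anilides: inverting a ring stereocentre

The source may report more compounds than this note shows. Statements on the series, on what has been measured and on what is new or still open speak of the compounds shown alone.

Measured so far in a functional assay on A549 cells (Homo sapiens) for cytotoxicity, read by MTT assay, with a stated time of 48 h; on this read-out higher numbers stand for weaker inhibition and lower numbers for stronger inhibition:
compound 1 `COc1cc([C@H]2C[C@]2(CO)C(=O)Nc2ccccc2Cl)cc(OC)c1OC`: 36700 nM
compound 2 `COc1cc([C@@H]2C[C@@]2(CO)C(=O)Nc2ccccc2)cc(OC)c1OC`: 43200 nM
compound 3 `COc1cc([C@@H]2C[C@]2(CO)C(=O)Nc2ccccc2)cc(OC)c1OC`: 24100 nM

All three numbers sit within a narrow band. Compound 3 gives the smallest of them, but its gap to compound 1 and its gap to compound 2 are both within the usual scatter, so no ordering among the three can be read from this assay.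

Within the data shown here, the one step that bears on the next compound is the configurational one: a 1.8-fold lower number from compound 2 to compound 3 (0.25 log units; within the scatter). Its only basis is the fact that compounds 2 and 3 differ only in the configuration as drawn, and the step itself stays inside the scatter.

Compound 4 `COc1cc([C@H]2C[C@]2(CO)C(=O)Nc2ccccc2)cc(OC)c1OC` is not yet measured in this assay. It differs from compound 3 as follows: the two compounds have the same atoms and bonds and differ only in configuration as drawn: 1 of 2 stereo elements differ; a stereocentre at a saturated ring carbon is drawn S in compound 3 and R in compound 4. Among the measured compounds shown here, this is the same kind of change as the one between compound 2 and compound 3, which produced no step beyond the scatter. On that precedent the change is expected to leave the number essentially unmoved, with no direction favoured.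

The estimate for compound 4 in this assay is therefore 32000 nM, with a range from 14000 nM to 75000 nM. The expected step is a 1.3-fold higher number from compound 3 to compound 4 (0.12 log units; within the scatter), which lies within the scatter.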

Compound 4, half-maximal inhibitory concentration: > 100000 nM
Compound 4: no number, only a limit; the forecaster's own chance of this, stated with the estimate: 10%; middle value at least 3.1-fold (0.49 log units) from the limit.
By their numbers in this assay, from the lowest: compounds 3, 1 and 2 (each within the scatter of the next). At a limit, above all of these: compound 4.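

In this assay compound 4 gives > 100000 nM, which is a limit of the assay and not a number. Inverting the other of the two ring stereocentres gives an at least 4.1-fold higher number from compound 3 to compound 4 (0.61 log units; beyond the scatter) and inverting both gives an at least 2.3-fold higher number from compound 2 to compound 4 (0.36 log units; beyond the scatter), whereas inverting one alone gave a 1.8-fold lower number from compound 2 to compound 3 (0.25 log units; within the scatter), so the two stereocentres do not count alike in these anilides, and the gap can only be configurational: the fact that compounds 3 and 4 differ only in the configuration as drawn. The chloro anilide drawn in the same configuration still gives a measured number, and hydrogen in place of chloro on an aromatic carbon gives an at least 2.7-fold higher number from compound 1 to compound 4 (0.43 log units; beyond the scatter), so this configuration does not set the outcome independently of the aromatic substituent.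

The series shown holds a chloro anilide in one configuration only, so whether chloro has any bearing in the other configurations stays open. Also open, from the compounds shown here alone, are how far compound 4 lies past its limit and whether an amine in place of chloro, or a carboxylic acid in place of the hydroxymethyl group, would give a measured number in this configuration.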